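The compounds below may be only part of what the source reports. "The series", "measured", "known", "first", "only" and "open" are said of these compounds alone.

In a functional assay on CCRF-CEM cells (Homo sapiens) for cytotoxicity, with a stated time of 72 h (a lower number here means a stronger inhibitor, a higher number a weaker inhibitor), compound 1 `C#CCOc1ccc(/C=C/C(=O)c2cccc(OC)c2)cc1OC` gives 5590 nM. Compound 2 `C#CCOc1ccc(/C=C/C(=O)c2ccc(CC=C(C)C)cc2)cc1OC` reaches only a limit in this assay, > 50000 nM; this is the limit of > 50000 nM in this assay, at which 1 of the 2 values shown sits. No number stands for compound 2, and the gap between compound 2 and compound 1 cannot be sized. Compound 3 `C#CCOc1ccc(/C=C/C(=O)c2ccc(-n3ccnc3)cc2)cc1OC` differs from compound 2 by 1H-imidazol-1-yl in place of 3-methylbut-2-en-1-yl on an aromatic carbon. With only a limit for compound 2, the step cannot be set against a measured value; the expectation is a move towards stronger inhibition, from compound 2 to compound 3 roughly an at least 3.3-fold lower number from compound 2 to compound 3 (0.52 log units; beyond the scatter). Compound 3 is estimated at 15000 nM in this assay, between 3000 nM and 50000 nM.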

Compound 3, half-maximal inhibitory concentration: 15000 nM
Compound 3: the middle estimate sits on the measured number at the digits printed, within the range that was stated.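

At this position, on an aromatic carbon para to a large group, the substituent matters in this assay: 1H-imidazol-1-yl in place of 3-methylbut-2-en-1-yl gives an at least 3.3-fold lower number from compound 2 to compound 3 (0.52 log units; beyond the scatter). The two groups match in heavy-atom count, while the entering group brings a five-membered aromatic ring and hydrogen-bond acceptors. Compound 2 stands only at a limit, so the step has a lower bound and no full size: the limit of > 50000 nM in this assay, at which 1 of the 3 values shown sits.

Open, as far as these compounds go, is whether the ring nitrogens matter or any aromatic ring would serve here. A phenyl ring or a dimethylamino group at this position would help separate these readings.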